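The source may report more compounds than this note shows. Statements on the series, on what has been measured and on what is new or still open speak of the compounds shown alone.

Measured so far:
- compound 1 `Cc1ccc(/C=C/C(=O)c2ccccc2NC(=O)NS(=O)(=O)c2ccc(C)cc2)cc1`, which in an ADME assay on the whole organism for cytotoxicity, with Artemia salina as the target, with a stated time of 24 h (on this read-out higher numbers stand for an effect only at larger amounts of compound and lower numbers for an effect already at smaller amounts), gives 15.3 ug/mL
- compound 2 `COc1cc(/C=C/C(=O)c2ccccc2NC(=O)NS(=O)(=O)c2ccc(C)cc2)ccc1O`, which in this assay gives 17.8 ug/mL

On these two numbers compound 2 stands highest, but its nearest neighbour, compound 1, sits within the usual scatter of repeated measurements, so the two cannot be ordered with confidence. For the measured compounds named here, the only step measured, a 1.2-fold higher number from compound 1 to compound 2 (0.07 log units; within the scatter), exchanged one aromatic group for another at the same place and left the read-out essentially unchanged.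

Compound 3 `Cc1ccc(S(=O)(=O)NC(=O)Nc2ccccc2C(=O)/C=C/c2cccc(Br)c2)cc1` has not yet been measured. It differs from compound 2 in one place: 3-bromophenyl in place of 4-hydroxy-3-methoxyphenyl on a double-bonded chain carbon bound to a double-bonded chain carbon. The step from compound 1 to compound 2 is the only one that bears on this change, since it altered the same position, and it stayed within the scatter. No step beyond the scatter is therefore expected here: a 1.1-fold lower number from compound 2 to compound 3 (0.05 log units; within the scatter). Compound 3 is estimated at 16 ug/mL, with a likely range from 8 ug/mL to 32 ug/mL.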

Compound 3, concentration for half-maximal effect: 4.02 ug/mL
Beside the measured number, compound 3's estimate is 4.0-fold (0.60 log units) above it, outside the stated range (below it).
By their numbers in this assay, from the lowest: compound 3; then compounds 1 and 2 (each within the scatter of the next).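

This position on the chain can clearly move the read-out. In this assay, 3-bromophenyl brings a 4.4-fold lower number from compound 2 to compound 3 (0.65 log units; beyond the scatter) and a 3.8-fold lower number from compound 1 to compound 3 (0.58 log units; beyond the scatter), whereas the exchange of 4-methylphenyl for 4-hydroxy-3-methoxyphenyl, a 1.2-fold higher number from compound 1 to compound 2 (0.07 log units; within the scatter), stayed within the scatter. The ring carrying bromine therefore stands apart from the other two, with an effect already at smaller amounts of compound, but nothing at hand says what lies behind this shift.

Only one bromine-bearing ring is shown, so it remains open whether the bromine itself matters or whether any other group at that place on the phenyl ring would do the same. A phenyl ring carrying chlorine, a nitrile or an amine in place of the bromine would help separate these possibilities.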